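The source may hold more compounds than are shown below. What is called first, only, known or untested is meant among the compounds shown, and "the series" means these compounds.

Compound 1 `C#CCSc1nc2cc(Cl)c(Cl)cc2n1C1O[C@H](CO)[C@@H](O)[C@H]1O`: 60000 nM
Compound 2 `OC[C@H]1OC(n2c(SCc3ccc(Br)cc3)nc3cc(Cl)c(Cl)cc32)[C@H](O)[C@@H]1O`: 20000 nM

In a functional assay on KB cells (Homo sapiens) for inhibition (a lower number here means a stronger inhibitor, a higher number a weaker inhibitor), compound 2 gives the lowest of the two numbers; its nearest neighbour is compound 1 at 60000 nM. Compound 3 `O=[N+]([O-])c1cccc(CSc2nc3cc(Cl)c(Cl)cc3n2C2O[C@H](CO)[C@@H](O)[C@H]2O)c1` differs from compound 2 by 3-nitrophenyl in place of 4-bromophenyl on a saturated chain carbon bound to a sulfur. Going by the values given here, the only measured step, a 3.0-fold lower number from compound 1 to compound 2 (0.48 log units; beyond the scatter), concerns a different exchange and says nothing direct about swapping one aryl group for another. Among the compounds with values here, with no step bearing on this change, compound 3 is expected to sit close to compound 2, with no change at the digits printed from compound 2 to compound 3 (within the scatter) not beyond the scatter. For compound 3 the estimate is 20000 nM, within 7000 nM to 60000 nM.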

Compound 3, half-maximal inhibitory concentration: 25000 nM
Compound 3: middle estimate off by 1.3-fold (0.10 log units), on the low side, within the range that was stated.
By their numbers in this assay, from the lowest: compounds 2 and 3 (each within the scatter of the next); then compound 1.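

In this assay the change from 4-bromophenyl to 3-nitrophenyl on a saturated chain carbon bound to a sulfur gives a 1.3-fold higher number from compound 2 to compound 3 (0.10 log units; within the scatter) and so does not separate the two aryl groups, despite their different substituents. The exchange of ethynyl for 3-nitrophenyl gives a 2.4-fold lower number from compound 1 to compound 3 (0.38 log units; beyond the scatter), so a second aryl group also stays clear of the ethynyl compound. No measurement here explains this behaviour.

From the compounds shown here alone, whether an amine or a carboxylic acid in place of the aryl group would shift the number remains open. Also open, going by these compounds, is the separate contribution of substituent and ring position, since 4-bromophenyl and 3-nitrophenyl differ in both.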